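A few compounds are considered here, and "the series" means these few. Any claim that something is new, unique, unknown or untested is made for them only; others in the source may bear on it.

Measured compounds:
- compound 1 `C[C@@H](NC(=O)[C@H](CCCNC(=N)N)NC(=O)c1ccc(CN(Cc2ccccn2)C(=O)c2ccc(F)cc2)cc1)c1cccc2ccccc12`: 3%
- compound 2 `C[C@@H](NC(=O)[C@H](CCCNC(=N)N)NC(=O)c1ccc(CN(Cc2cccnc2)C(=O)c2ccc(F)cc2)cc1)c1cccc2ccccc12`: 11%
- compound 3 `C[C@H](NC(=O)[C@H](CCCNC(=N)N)NC(=O)c1ccc(CN(Cc2ccc(F)cc2)Cc2ccccn2)cc1)c1cccc2ccccc12`: 30%

In an assay on Jurkat cells for displacement of a labelled ligand from C-X-C chemokine receptor type 4 (Homo sapiens), tested at 10 uM (a lower number here means less inhibition, a higher number more inhibition at the concentration tested (going by the name of the read-out)), compound 1 gives 3%. Compound 2 gives 11% in this assay, and compound 3 gives 30%. The change from compound 1 to compound 2 is pyridin-3-yl in place of pyridin-2-yl on a saturated chain carbon bound to an amide-type nitrogen, and its step is a number 8 percentage points higher from compound 1 to compound 2 (within the scatter). Compound 3 carries the highest of the three numbers, and its distance to compound 2 and to compound 1 is in each case beyond the scatter; the difference between the core of compound 3 and the core of compound 1 is not broken down here.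

Compound 4 `C[C@H](NC(=O)[C@H](CCCNC(=N)N)NC(=O)c1ccc(CN(Cc2ccc(F)cc2)Cc2cccnc2)cc1)c1cccc2ccccc12` has not yet been measured in this assay. It differs from compound 3 by pyridin-3-yl in place of pyridin-2-yl on a saturated chain carbon bound to an amine nitrogen. This is the same kind of change as that from compound 1 to compound 2, not the same: there the place is on a saturated chain carbon bound to an amide-type nitrogen, here on a saturated chain carbon bound to an amine nitrogen. Among the measured compounds shown here, the one measured instance of this change, a number 8 percentage points higher from compound 1 to compound 2 (within the scatter), lies within the scatter, so the expectation for compound 4 is a step close to that, with compound 3 as the reference point. The step estimated from compound 3 to compound 4 is a number 4 percentage points higher from compound 3 to compound 4 (within the scatter). For the measured compounds named here, compound 4 is therefore expected to give about 34%, in a range from 18% to 50%, resting on the single step of a number 8 percentage points higher from compound 1 to compound 2 (within the scatter) and on the value of compound 3, 30%.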

Compound 4, a percentage reported as inhibition, at one concentration (the size of the read-out at that concentration, not a potency): 27%
Compound 4: middle estimate off by 7 percentage points, on the high side; the range from low to high includes it.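

In this assay, pyridin-3-yl in place of pyridin-2-yl on a saturated chain carbon bound to an amine nitrogen gives a number 3 percentage points lower from compound 3 to compound 4 (within the scatter). Set beside the earlier instance of this change on the other core, the two steps do not differ: the same change on two cores in this assay, a number 8 percentage points higher (within the scatter) from compound 1 to compound 2 and a number 3 percentage points lower (within the scatter) from compound 3 to compound 4, 11 percentage points apart, within the scatter of two such steps On these two cores, then, the change from (pyridin-2-yl)methyl to (pyridin-3-yl)methyl leaves the read-out within the scatter each time, and no dependence on the core can be seen; this rests on only two pairs, read at a single concentration, and so it shows neither that the two groups are equal in potency nor that the same would hold on a further core.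

Among the compounds shown here, no single-place pair connects the core of compound 1 with the core of compound 3, so what separates those two cores remains open. Also open, as far as these compounds go, is how the series responds when the pyridine ring gives way to a plain phenyl, or when a longer chain or a carboxylic acid stands in place of the (pyridin-2-yl)methyl group.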